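The compounds below may be only part of what the source reports. "The series", "measured", "known", "first", "only" and "open" are said of these compounds alone.

Compound 1 `CCOC(=O)CCCCCOc1cccc(CN(C(=O)c2ccc(-c3cccc4ccccc34)cc2)C(C)C)c1`, compound 2 `CCOC(=O)CCCCCOc1cccc(CN(C(=O)c2ccc(-c3cccnc3)cc2)C(C)C)c1` and compound 3 `CCOC(=O)CCCCCOc1cccc(CN(C(=O)c2ccc(-c3cccc(OC)c3)cc2)C(C)C)c1` share one core and differ only in the group attached to an aromatic carbon at one end. In an ADME assay on HEK293 cells (Homo sapiens) for cytotoxicity, read by CellTiter-Glo and resazurin assay, with a stated time of 72 h (on this read-out higher numbers stand for an effect only at larger amounts of compound and lower numbers for an effect already at smaller amounts), compound 1 gives > 26000 nM, which is a limit of the assay and not a number. In this assay compound 2 gives > 26000 nM, again a limit. Compound 3 gives > 21000 nM in this assay, also a limit. On these data alone, because of the limit of > 21000 nM in this assay, at which 1 of the 3 values shown sits, and the limit of > 26000 nM in this assay, at which 2 of the 3 values shown sit, none of the steps between these three can be read: a step that the two limits leave unreadable from compound 1 to compound 2, a step that the two limits leave unreadable from compound 1 to compound 3 and a step that the two limits leave unreadable from compound 2 to compound 3 all stay open. Compound 3 therefore stands at a limit, like the two others, with no order among the three. Compound 4 `CCOC(=O)CCCCCOc1cccc(CN(C(=O)c2ccc(-c3cccc(OCC)c3)cc2)C(C)C)c1` differs from compound 3 by methyl in place of hydrogen on a saturated chain carbon bound to an oxygen on an aromatic ring. Going by the values given here, no measured step covers this change, and the three steps that exist are unreadable, so in this assay no step beyond the scatter is expected in either direction. The step from compound 3 that is expected reads a step that the limit leaves unreadable from compound 3 to compound 4. Compound 4 is thus estimated at 30000 nM, with a range from 10000 nM to 100000 nM, and most likely reported only as a limit again.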

Compound 4, half-maximal effective concentration: > 22300 nM
Compound 4 was reported as a limit; the forecaster's own chance of this, stated with the estimate: 80%; the middle value is on the limit's open side.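

Going by these compounds alone, compound 4 stands at a limit in this assay, as do compound 1, compound 2 and compound 3, so no step from any of them to compound 4 can be read. The compounds shown leave open at what concentration any of them has an effect, and whether changing the end group, including methoxy to ethoxy, shifts that concentration.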